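Compound 3 to compound 4: one methyl fewer

The compounds below may be only part of what the source reports. "The series", "measured", "known", "first", "only" and "open" are said of these compounds alone.

Compound 1 `CC(C)(CO)CNC(=O)c1cc2cc(C#N)ccc2n1Cc1cccc(OC(F)(F)F)c1`: < 6 mL.min-1.g-1
Compound 2 `COc1ccc(Cl)cc1Cn1c(C(=O)NCC(C)(C)CO)cc2cc(C#N)ccc21`: < 6 mL.min-1.g-1
Compound 3 `CC(C)(O)CCNC(=O)c1cc2cc(C#N)ccc2n1Cc1cccc(OC(F)(F)F)c1`: < 6 mL.min-1.g-1

All three results come from an in vitro ADME assay on microsomes from Gut (Homo sapiens) for metabolic stability, using NADPH (on this read-out higher numbers stand for fast clearance and lower numbers for slow clearance), and none of them is a number: the limit of < 6 mL.min-1.g-1 in this assay, at which 3 of the 3 values shown sit. As far as these compounds go, compound 3 therefore has only a limit, < 6 mL.min-1.g-1, and its true place under that limit is unknown.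

Compound 4 `CC(O)CCNC(=O)c1cc2cc(C#N)ccc2n1Cc1cccc(OC(F)(F)F)c1` differs from compound 3 in one place: hydrogen in place of methyl on a saturated chain carbon bound to an oxygen on a saturated carbon and two saturated chain carbons. The 3-hydroxy-3-methylbutyl group becomes 3-hydroxybutyl.

For the measured compounds named here, the only measured step that bears on this change is a step that the two limits leave unreadable from compound 1 to compound 3. Going by the values given here, it alters the same chain but gives no size, and no measured step removes this methyl. The data thus support no expected direction, and no step beyond the scatter is expected in this assay. The expected change is a step that the limit leaves unreadable from compound 3 to compound 4. This expectation rests on compound 3 and its limit of < 6 mL.min-1.g-1. For compound 4 the estimated value is 5 mL.min-1.g-1, with an expected range from 3 mL.min-1.g-1 to 9 mL.min-1.g-1.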

Compound 4, intrinsic clearance in microsomes: < 6 mL.min-1.g-1
Compound 4: only a limit was reported; the forecaster's own chance of this, stated with the estimate: 80%; the middle value does not contradict the limit.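

No new step can be read in this assay from compound 1 or compound 3 to compound 4, because these results are limits and not numbers: the limit of < 6 mL.min-1.g-1 in this assay, at which 4 of the 4 values shown sit.

The compounds shown leave open where each true clearance lies under that limit, and whether hydrogen in place of methyl changes it at all.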